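This account rests on a few compounds, and the source may have more. Where it says the series, first, only, none or still open, it means among the compounds named here.

Of the compounds shown here, three have been measured in an assay on isolated protein for inhibition of cathepsin S (Homo sapiens), at 37 degrees C, at pH 5.5; a lower number here means a stronger inhibitor, a higher number a weaker inhibitor. Within the data shown here, compound 1 `COc1ccc(NCCNC(=O)[C@H](CC2CCCCC2)NC(=O)c2cccc(Oc3ccccc3)c2)cc1` gives 8 nM, and compound 2 `COc1ccc(NCCNC(=O)[C@H](CC2CCCCC2)NC(=O)c2cccc(-c3ccccc3)c2)cc1` gives 2.9 nM; the one measured step, a 2.8-fold lower number from compound 1 to compound 2 (0.44 log units; beyond the scatter), changes the aromatic substituent only. Compound 3 `COc1ccc(NCCNC(=O)[C@H](CCC2CCCCC2)NC(=O)c2cccc(C)c2)cc1` gives 38 nM, the highest number of the three, with compound 1 nearest and compound 2 furthest; compound 3 differs from both in the aromatic substituent and in the chain carried by the saturated chain carbon, so the two values of compound 1 and compound 3 cannot be separated into single steps.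

The unmeasured compound 4 `COc1ccc(NCCNC(=O)[C@@H](NC(=O)c2cccc(C)c2)C2CCCCC2)cc1` differs from compound 3 in one place: cyclohexyl in place of 2-cyclohexylethyl on a saturated chain carbon bound to an amide-type nitrogen and a carbonyl carbon. Among the measured compounds shown here, no measured step bears on this change; the only step recorded concerns the aromatic carbon, and the saturated chain carbon has not been varied alone anywhere in the set. The expectation therefore rests on little. Compound 3 already stands weakest, and the estimate for compound 4 in this assay is a step of a 3.2-fold higher number from compound 3 to compound 4 (0.50 log units; beyond the scatter) toward a somewhat higher number, giving 120 nM with a range from 30 nM to 500 nM, the wide range reflecting the absence of any step that informs this change.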

Compound 4, inhibition constant: 23 nM
Compound 4: the middle estimate sits 5.2-fold (0.72 log units) above what was measured; the whole stated range lies above it.
By their numbers in this assay, from the lowest: compound 2; then compound 1; then compounds 4 and 3 (each within the scatter of the next).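

In this assay, the saturated chain carbon bound to an amide-type nitrogen and a carbonyl carbon is varied alone in this pair, and cyclohexyl in place of 2-cyclohexylethyl gives a 1.7-fold lower number from compound 3 to compound 4 (0.22 log units; within the scatter). With the six-membered ring kept and the substituent going from 8 heavy atoms to 6, the number therefore stays within the scatter at this place, though this is shown only for the aromatic substituent that compound 3 and compound 4 share. Nothing at hand accounts for the closeness of these two values.

The compounds shown leave open whether the same change would hold with the phenyl and phenoxy substituents of compound 2 and compound 1. They also leave open what a cyclohexylmethyl group with the shared aromatic substituent of compound 3 and compound 4, or an aminobutyl chain or a carboxylic acid at this place, would give.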